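Swapping the benzyl tail of compound 1 for thiophen-3-yl

The compounds below may be only part of what the source reports. "The series", "measured", "known", "first", "only" and "open" are said of these compounds alone.

Compound 1 `O=c1[nH]/c(=N\OCCCCc2ccccc2)ccn1[C@@H]1O[C@H](COP(=O)(O)OP(=O)(O)OP(=O)(O)O)[C@@H](O)[C@H]1O` carries a tail that ends in a benzyl group. In a functional assay on 1321-N1 cells for agonist activity at P2Y purinoceptor 2 (Homo sapiens), read by scintillation counting and inositol phosphate accumulation (on this read-out lower numbers stand for an effect already at smaller amounts and higher numbers for an effect only at larger amounts of compound), compound 1 gives 214 nM, the lowest of the two numbers measured here, although compound 2 `O=c1[nH]/c(=N\OCCCc2ccncc2)ccn1[C@@H]1O[C@H](COP(=O)(O)OP(=O)(O)OP(=O)(O)O)[C@@H](O)[C@H]1O` lies within the scatter of it: compound 2 gives 285 nM. Within the data shown here, the single measured step, a 1.3-fold higher number from compound 1 to compound 2 (0.12 log units; within the scatter), shows that exchanging benzyl for pyridin-4-yl at this place leaves the number essentially where it was.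

Compound 3 `O=c1[nH]/c(=N\OCCCc2ccsc2)ccn1[C@@H]1O[C@H](COP(=O)(O)OP(=O)(O)OP(=O)(O)O)[C@@H](O)[C@H]1O` has not yet been measured. Its change from compound 1 is thiophen-3-yl in place of benzyl on a saturated chain carbon, three bonds along the chain from an oxygen. Among the measured compounds shown here, as in the step to compound 2, one aromatic ring replaces another at the same place, so that step is the only guide, and it stayed within the scatter. A step of similar size is therefore expected, a 1.2-fold higher number from compound 1 to compound 3 (0.07 log units; within the scatter), with no clear direction. Compound 3 is estimated at 250 nM, within a range from 120 nM to 550 nM.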

Compound 3, half-maximal effective concentration: 103 nM
For compound 3 the middle estimate is 2.4-fold (0.39 log units) above the measured one, outside the stated range (below it).
By their numbers in this assay, from the lowest: compound 3; then compounds 1 and 2 (each within the scatter of the next).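

In this assay, this position proves sensitive to which ring ends the tail, since thiophen-3-yl gives a 2.1-fold lower number from compound 1 to compound 3 (0.32 log units; beyond the scatter) and, set against pyridin-4-yl, gives a 2.8-fold lower number from compound 2 to compound 3 (0.44 log units; beyond the scatter). Both steps are modest but beyond the scatter, so the earlier step from benzyl to pyridin-4-yl, which stayed within the scatter, does not mean that any aromatic ring can stand in for another here. No measurement offered here explains why thiophen-3-yl gives the lower number.

From the compounds shown here alone, it remains open whether this result belongs to thiophen-3-yl alone or extends to other five-membered aromatic rings, such as thiophen-2-yl or furan-3-yl. Also open, going by these compounds, is how a shorter or longer chain carrying thiophen-3-yl would read out, or the same ring bearing an amine.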